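Urea series: first antiproliferative readings

This account rests on a few compounds, and the source may have more. Where it says the series, first, only, none or still open, it means among the compounds named here.

In a functional assay on KOPN-8 cells (Homo sapiens) for antiproliferative activity, with a stated time of 72 h (a lower number here means that less compound is needed, a higher number that more compound is needed for the effect), compound 1 `COc1ccc(-c2cc(=O)c3c(OC)cc(OC)cc3n2S(=O)(=O)Cc2ccccc2)cc1` gives only a limit, > 34400 nM. Compound 2 `COC(=O)c1cc(=O)c2cc(NC(=O)Nc3ccc(F)c(Cl)c3)ccc2[nH]1` likewise reaches only a limit in this assay, > 6350 nM. For the measured compounds named here, compound 2 thus stands at the limit (the limit of > 6350 nM in this assay, at which 1 of the 2 values shown sits), and the one further value shown sits at its own limit (the limit of > 34400 nM in this assay, at which 1 of the 2 values shown sits), so no measured step exists between the two compounds and nothing can be ranked. Compound 3 `COC(=O)c1cc(=O)c2cc(NC(=O)Nc3ccc4c(c3)CCC4)ccc2[nH]1` differs from compound 2 in one place: 2,3-dihydro-1H-inden-5-yl in place of 3-chloro-4-fluorophenyl on an amide-type nitrogen. Going by the values given here, with no measured step, no size or direction of change can be anchored to data. The expected step from compound 2 to compound 3 is a step that the limit leaves unreadable from compound 2 to compound 3, a shift not beyond the usual scatter. Compound 3 is estimated at 10000 nM in this assay, with a range from 2000 nM to 50000 nM, and a limit rather than a number is expected more often than not.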

Compound 3, half-maximal effective concentration: > 24100 nM
Compound 3: only a limit was reported; the forecaster's own chance of this, stated with the estimate: 70%; middle value at least 2.4-fold (0.38 log units) from the limit.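

Compound 3 gives only a limit in this assay, > 24100 nM. Compound 2 is likewise a limit, > 6350 nM, which leaves no readable step within this pair. The compounds shown leave open how 2,3-dihydro-1H-inden-5-yl and 3-chloro-4-fluorophenyl compare, and whether either gives a numerical value.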